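A fluoro group on a compound at the assay limit

The source may hold more compounds than are shown below. What is called first, only, known or untested is meant among the compounds shown, and "the series" means these compounds.

Compound 1 `Cc1cc(O)c(C(=O)/C=C/c2ccccc2)c(=O)o1` gives > 100000 nM
Compound 2 `Cc1cc(O)c(C(=O)/C=C/c2ccco2)c(=O)o1` gives > 100000 nM
Compound 3 `Cc1cc(O)c(C(=O)/C=C/c2ccc[nH]2)c(=O)o1` gives > 100000 nM

In a functional assay on HCT-116 cells (Homo sapiens) for cytotoxicity, read by MTT assay (on this read-out higher numbers stand for weaker inhibition and lower numbers for stronger inhibition), compound 1 gives > 100000 nM as a limit and not as a number. Compound 2 gives > 100000 nM as a limit too. Compound 3 gives > 100000 nM as a limit as well. The evidence is thin: the limit of > 100000 nM in this assay, at which 3 of the 3 values shown sit, is all that these compounds offer.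

Compound 4 `Cc1cc(O)c(C(=O)/C=C/c2cccc(F)c2)c(=O)o1` differs from compound 1 by a single change, fluoro in place of hydrogen on an aromatic carbon and nothing else. The measured steps a step that the two limits leave unreadable from compound 1 to compound 2 and a step that the two limits leave unreadable from compound 1 to compound 3 and also a step that the two limits leave unreadable from compound 2 to compound 3 all replace the whole aromatic group, and none has a readable size. With compound 1 at > 100000 nM as a limit, no step beyond the scatter is expected in this assay in either direction. The expected outcome is a number no higher from compound 1 to compound 4 (the limit leaves the size open) in size. For compound 4 the estimate is 100000 nM with an expected range from 40000 nM to 200000 nM.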

Compound 4, half-maximal inhibitory concentration: 81200 nM
The estimate for compound 4 lay 1.2-fold (0.09 log units) above the measured number; the measured number falls inside the stated range.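

In this assay compound 4 is the first of the compounds shown to give a number and not a limit, so a change on this six-membered aromatic ring can now be placed on the scale. Fluoro in place of hydrogen on an aromatic carbon, meta to a large group, comes with an at least 1.2-fold lower number from compound 1 to compound 4 (0.09 log units; that floor lies within the scatter). From the compounds shown here alone, the starting point of that step is a limit and not a number, so only a floor can be read and the true size of the step stays open: the limit of > 100000 nM in this assay, at which 3 of the 4 values shown sit.

The compounds shown leave open whether fluoro at another place on this ring would also give a number, and whether chloro, trifluoromethyl, methoxy or an amine at the same place would give a lower one. They also leave open whether fluoro on the furan-2-yl or 1H-pyrrol-2-yl ring would bring a number within reach.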